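Halogen Swap on the Aryl Ring: From Compound 3 to Compound 4

The source may report more compounds than this note shows. Statements on the series, on what has been measured and on what is new or still open speak of the compounds shown alone.

Three compounds sharing one core have been measured in a functional assay on PC-12 cells (Rattus norvegicus) for cytotoxicity, read by MTT assay, with stated times of 2 h and 24 h, tested at 5 uM; on this read-out lower numbers stand for a weaker effect and higher numbers for a stronger effect at the one concentration tested:

Compound 1, `Oc1cc(C(F)(F)F)ccc1-c1nc(-c2ccccc2O)n(-c2ccc(Br)cc2)n1`: 89.8%
Compound 2, `Oc1cc(C(F)(F)F)ccc1-c1nc(-c2ccccc2O)n(-c2ccccc2C(F)(F)F)n1`: 80%
Compound 3, `Oc1cc(C(F)(F)F)ccc1-c1nc(-c2ccccc2O)n(-c2cccc(F)c2)n1`: 87.7%

The three numbers lie close together. Compound 3 falls in the middle on the raw figures, but neither neighbour is separated from it by more than the scatter: the step of a number 2.1 percentage points lower from compound 1 to compound 3 (within the scatter) and the step of a number 7.7 percentage points higher from compound 2 to compound 3 (within the scatter) both stay inside it, as does the step of a number 9.8 percentage points lower from compound 1 to compound 2 (within the scatter) between the other two.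

Compound 4, `Oc1cc(C(F)(F)F)ccc1-c1nc(-c2ccccc2O)n(-c2cccc(Cl)c2)n1`, has not yet been measured. It differs from compound 3 in one place: chloro in place of fluoro on an aromatic carbon. Cut one bond further out, the same difference reads 3-fluorophenyl to 3-chlorophenyl.

Going by the values given here, every measured step so far has varied the aryl group on the aromatic nitrogen, and none of them moved the read-out beyond the scatter, even when the whole aryl group was exchanged, as in the step of a number 2.1 percentage points lower from compound 1 to compound 3 (within the scatter). A swap of one halogen for another at the same place is a smaller change than any of those. The step of a number 1.7 percentage points lower from compound 3 to compound 4 (within the scatter) is therefore expected to stay within the scatter. Compound 4 is estimated to give 86%, with a range from 74% to 96%.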

Compound 4, a percentage reported as activity, at one concentration (the size of the read-out at that concentration, not a potency): 92.7%
Estimate against measurement, compound 4: 6.7 percentage points below; measured number inside the range.
By their numbers in this assay, from the lowest: compounds 2, 3, 1 and 4 (each within the scatter of the next, the first and the last beyond it).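

In this assay, the change from 3-fluorophenyl to 3-chlorophenyl gives a number 5 percentage points higher from compound 3 to compound 4 (within the scatter), so at this place on the ring one halogen can stand in for the other with no readable change at the one concentration tested. Going by these compounds alone, the new compound also supplies the first step in the set that clears the scatter, the modest a number 12.7 percentage points higher from compound 2 to compound 4 (beyond the scatter), while a number 2.9 percentage points higher from compound 1 to compound 4 (within the scatter) does not, which means that among exchanges of the aryl group on the aromatic nitrogen only this one pair can be told apart, and compound 1 and compound 3 each remain within the scatter of compound 2. No supporting data are available to account for that single separation.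

The compounds shown leave open whether an amine or a carboxylic acid at the same place on the phenyl ring would keep the read-out in this narrow band. They also leave open how compound 4 and compound 2 would compare at other concentrations, as a reading at one concentration gives the size of an effect and not a potency.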